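Phenoxy in Place of tert-Butyl on a Shared Core

The compounds below may be only part of what the source reports. "The series", "measured", "known", "first", "only" and "open" are said of these compounds alone.

Of the compounds shown here, two built on one shared core have so far been measured in a functional assay on brain (Rattus norvegicus, strain Wistar) for inhibition; on this read-out lower numbers stand for stronger inhibition and higher numbers for weaker inhibition. Compound 1 `Cc1[nH]c(=O)n(C)c1-c1ccc(C(C)(C)C)cc1` gives 8400 nM, the higher of the two numbers. Compound 2 `CCCCCCCCOc1ccc(-c2c(C)[nH]c(=O)n2C)cc1` gives 4000 nM in this assay, a lower number by a margin beyond the usual scatter. Among the measured compounds shown here, no step between these two is counted here, so only their two values speak.

Compound 3 `Cc1[nH]c(=O)n(C)c1-c1ccc(Oc2ccccc2)cc1` has not yet been measured in this assay. It differs from compound 1 in one place: phenoxy in place of tert-butyl on an aromatic carbon. Because compound 2, which also carries an oxygen-linked group on the same ring, gives 4000 nM, a move toward lower numbers seems plausible for compound 3. The step of a 1.7-fold lower number from compound 1 to compound 3 (0.23 log units; within the scatter) is expected to be modest, toward lower numbers and near the edge of the usual scatter. Compound 3 is therefore estimated at about 5000 nM, most likely between 1500 nM and 15000 nM.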

Compound 3, half-maximal inhibitory concentration: 8100 nM
Beside the measured number, compound 3's estimate is 1.6-fold (0.21 log units) below it, and the stated range covers the measured number.
By their numbers in this assay, from the lowest: compound 2; then compounds 3 and 1 (each within the scatter of the next).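

In this assay the exchange of tert-butyl for phenoxy on an aromatic carbon amounts to a 1.0-fold lower number from compound 1 to compound 3 (0.02 log units; within the scatter) and so leaves the read-out level. This position therefore accepts a group of 7 heavy atoms, with a six-membered aromatic ring and a hydrogen-bond acceptor, in place of one of 4 heavy atoms with no ring, and the number stays within the scatter. Nothing available bears on why these two groups read alike.

Whether any group at this place can move the number beyond the scatter remains open for the pair shown, since both groups carry no net charge and no hydrogen-bond donor. A carboxylic acid, an amine or a small methoxy group on the same aromatic carbon would each test this further.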